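A few compounds are considered here, and "the series" means these few. Any claim that something is new, unique, unknown or untested is made for them only; others in the source may bear on it.

In a functional assay on A549 cells (Homo sapiens) for antiproliferative activity, read by MTT assay, with a stated time of 72 h (on this read-out lower numbers stand for stronger inhibition and higher numbers for weaker inhibition), three compounds that share a core and differ in one group on a saturated chain have been measured: compound 1 `CCN(CC)CCCOc1cc2ncnc(Nc3ccc(C#N)cc3)c2cc1OC` gives 50600 nM, compound 2 `COc1cc2c(Nc3ccc(C#N)cc3)ncnc2cc1OCCCN1CCCCC1` gives 23500 nM, and compound 3 `CCOC(=O)C1CCN(CCCOc2cc3ncnc(Nc4ccc(C#N)cc4)c3cc2OC)CC1` gives 89900 nM. Two steps show where the last of these stands. There is a 3.8-fold higher number from compound 2 to compound 3 (0.58 log units; beyond the scatter), and there is a 1.8-fold higher number from compound 1 to compound 3 (0.25 log units; within the scatter), so only the first of these gaps is a real one.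

Compound 4 `COc1cc2c(Nc3ccc(C#N)cc3)ncnc2cc1OCCCN1CCC(N2CCCCC2)CC1` differs from compound 3 in one group, with piperidin-1-yl in place of ethoxycarbonyl on a saturated ring carbon. The closest guide is the step that put ethoxycarbonyl onto that ring in place of hydrogen, a 3.8-fold higher number from compound 2 to compound 3 (0.58 log units; beyond the scatter). Among the measured compounds shown here, compound 4 loses that ethoxycarbonyl but carries another large group there, and no measured compound has piperidin-1-yl at this ring carbon, so the guide is only partial. The remaining step, a 2.2-fold lower number from compound 1 to compound 2 (0.33 log units; beyond the scatter), is also modest, and no step among these three compounds is large. A modest move toward a lower number is therefore expected, and the estimated step in this assay is a 2.6-fold lower number from compound 3 to compound 4 (0.41 log units; beyond the scatter). Compound 4 is estimated at 35000 nM, with an expected range from 12000 nM to 90000 nM.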

Compound 4, half-maximal inhibitory concentration: 30700 nM
For compound 4 the middle estimate is 1.1-fold (0.06 log units) above the measured one; the measured number falls inside the stated range.
By their numbers in this assay, from the lowest: compounds 2, 4, 1 and 3 (each within the scatter of the next, the first and the last beyond it).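

In this assay the exchange of ethoxycarbonyl for piperidin-1-yl on this saturated ring carbon gives a 2.9-fold lower number from compound 3 to compound 4 (0.47 log units; beyond the scatter), so a large group here does not by itself carry the higher number seen with ethoxycarbonyl, since the entering group has slightly more heavy atoms than the one that leaves. With hydrogen at the same carbon the picture is flat, at a 1.3-fold higher number from compound 2 to compound 4 (0.12 log units; within the scatter), and the whole 4-(piperidin-1-yl)piperidin-1-yl group also stays within the scatter of diethylamino, at a 1.6-fold lower number from compound 1 to compound 4 (0.22 log units; within the scatter), so among these compounds only ethoxycarbonyl sets the ring carbon apart from hydrogen. Nothing measured here explains why these two groups differ.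

The compounds shown leave open whether the ester itself matters, which a carboxylic acid or a primary amide at this ring carbon would test. They also leave open whether the nitrogen of the entering ring counts, which could be tested by comparing piperidin-1-yl with cyclohexyl, a ring of carbon atoms only, or with morpholin-4-yl, a ring that also holds an oxygen.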